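A few compounds are considered here, and "the series" means these few. Any claim that something is new, unique, unknown or untested is made for them only; others in the source may bear on it.

For the measured compounds named here, in a functional assay on L1210 cells (Mus musculus) for antiproliferative activity, read by MTT assay, with a stated time of 2 days (on this read-out lower numbers stand for stronger inhibition and higher numbers for weaker inhibition), two compounds have numbers so far. Compound 1 (`Cc1ccc(C#Cc2cn(C/C=C\CN3C(=O)c4ccccc4C3=O)c(=O)[nH]c2=O)cc1`) gives 245000 nM, the higher of the two and so the weaker inhibition. Compound 2 (`CCCCc1ccc(C#Cc2cn(C/C=C/CN3C(=O)c4ccccc4C3=O)c(=O)[nH]c2=O)cc1`) gives 42000 nM, a gap that lies beyond the usual scatter. Compound 3 (`O=C1c2ccccc2C(=O)N1C/C=C\Cn1cc(C#CCCc2ccccc2)c(=O)[nH]c1=O`) has not yet been measured in this assay. It keeps the core of compound 1 and carries phenethyl in place of 4-methylphenyl on a triple-bonded carbon. Going by the values given here, no measured pair shows this change on its own, and compound 2 differs from compound 1 in more than one place. The value of 42000 nM for compound 2 therefore shows only that a lower number occurs among these two compounds, not what this exchange will do. A modest step toward a lower number is expected in this assay, one that may not clear the scatter by much. For compound 3 the expected value is 120000 nM, with an estimated range of 40000 nM to 350000 nM. That estimate amounts to an expected 2.0-fold lower number from compound 1 to compound 3 (0.31 log units; beyond the scatter).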

Compound 3, half-maximal inhibitory concentration: 143000 nM
Compound 3: the middle estimate sits 1.2-fold (0.08 log units) below what was measured; the measured number falls inside the stated range.
By their numbers in this assay, from the lowest: compound 2; then compounds 3 and 1 (each within the scatter of the next).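

In this assay, for the compounds shown here, the exchange of 4-methylphenyl for phenethyl on a triple-bonded carbon gives the only single-place comparison available here, and it reads a 1.7-fold lower number from compound 1 to compound 3 (0.23 log units; within the scatter). At this position, therefore, going from 7 heavy atoms to 8 while keeping one six-membered aromatic ring of carbon only leaves the two numbers indistinguishable, which compound 2 could not show since it differs from compound 1 in more than one place. No independent measurement is available to explain this outcome.

The compounds shown leave open whether any group on this triple-bonded carbon can move the number beyond the scatter, for instance a longer chain ending in a phenyl ring, or a chain ending in an amine or a carboxylic acid. They also leave open which of the differences in compound 2 accounts for its number, as no pair here isolates any one of them.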